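The source may report more compounds than this note shows. Statements on the series, on what has been measured and on what is new or still open speak of the compounds shown alone.

Of the compounds shown here, two sharing one core have been tested in a functional assay on HepG2 cells (Homo sapiens) for cytotoxicity; a lower number here means a stronger inhibitor, a higher number a weaker inhibitor. Compound 1 (`CC(=O)OCC1=C[C@H](OCc2ccc3ccccc3c2)[C@H](O)[C@@H](O)C1=O`) gives > 50000 nM as a limit of the assay, not a number. Compound 2 (`CO[C@H]1C=C(COC(C)=O)C(=O)[C@H](O)[C@H]1O`) gives > 50000 nM as a limit too. Neither compound therefore yields a number, and both sit at the same point (the limit of > 50000 nM in this assay, at which 2 of the 2 values shown sit). Compound 3 (`CCCCCCCO[C@H]1C=C(COC(C)=O)C(=O)[C@H](O)[C@H]1O`) differs from compound 2 by one change, hexyl in place of hydrogen on a saturated chain carbon bound to an oxygen on a saturated carbon in the counted terms, which cut one bond further out reads methyl to heptyl. Because compound 1 gives > 50000 nM with its own, different ether group, no large gain is expected. The expected step, an at least 1.2-fold lower number from compound 2 to compound 3 (0.09 log units; that floor lies within the scatter) in this assay, is small and toward stronger inhibition, and the assay may again report only a limit. For compound 3 the estimate is 40000 nM as a central value, with an expected range from 12000 nM to 80000 nM as its span.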

Compound 3, half-maximal inhibitory concentration: > 50000 nM
Compound 3: only a limit was reported; the forecaster's own chance of this, stated with the estimate: 60%; at least 1.2-fold (0.09 log units) between middle value and limit.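

In this assay compound 3 gives > 50000 nM, a limit of the assay and not a number. Compound 2 is also reported only as a limit, so no step can be read between compound 2 and compound 3: the limit of > 50000 nM in this assay, at which 3 of the 3 values shown sit. The compounds shown leave open whether hexyl in place of hydrogen changes the read-out in this assay at all.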